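Removing the fluoro group from compound 2

The source may report more compounds than this note shows. Statements on the series, on what has been measured and on what is new or still open speak of the compounds shown alone.

Compound 1 `Cc1ccc(-c2n[nH]cc2N2CCCNCC2)cc1`: in an assay on isolated protein for binding affinity to 5-hydroxytryptamine receptor 4 (Homo sapiens) (on this read-out higher numbers stand for weaker inhibition and lower numbers for stronger inhibition), compound 1 gives > 10000 nM, a limit of the assay.
Compound 2 `Fc1cccc(-c2n[nH]cc2N2CCCNCC2)c1`: in this assay compound 2 gives > 10000 nM, a limit of the assay.
Compound 3 `COc1cccc(-c2n[nH]cc2N2CCCNCC2)c1`: in this assay compound 3 gives > 10000 nM, a limit of the assay.

All three measured compounds sit at the same limit of the assay, and this is the whole of the evidence: the limit of > 10000 nM in this assay, at which 3 of the 3 values shown sit. Compound 2 therefore stands nowhere on a scale of numbers; it is known only to lie at or beyond that limit, as do the two other compounds that share its core.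

For the measured compounds named here, the only measured step between neighbours, from compound 2 to compound 3, is a step that the two limits leave unreadable from compound 2 to compound 3. Both of its ends are limits of the assay. Its size cannot be read.

Compound 4 `c1ccc(-c2n[nH]cc2N2CCCNCC2)cc1` differs from compound 2 by hydrogen in place of fluoro on an aromatic carbon. Going by the values given here, no measured step bears on this change directly, and the one step that exists is unreadable. The closest guide is that every variation of the group on this ring, among compounds 1, 2 and 3, has left the affinity at the limit. Compound 4 is therefore expected to remain there as well, with the step from compound 2 to compound 4 estimated as a step that the limit leaves unreadable from compound 2 to compound 4, meaning no change that the assay could resolve. For compound 4 the estimated value in this assay is 20000 nM, with a range from 8000 nM to 60000 nM, and most likely the assay again reports only a limit.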

Compound 4, inhibition constant: > 10000 nM
Compound 4: no number, only a limit (the forecaster's own chance of this, stated with the estimate: 85%); the middle value is on the limit's open side.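

Compound 4 adds no readable step: the steps from compounds 1, 2 and 3 to compound 4 cannot be read in this assay, as each has a limit of the assay at both ends. The compounds shown leave open how far each lies beyond that limit, and whether any of these groups on the ring changes the affinity at all.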